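The compounds below may be only part of what the source reports. "The series", "measured", "known", "first", "only" and "open" are said of these compounds alone.

Working notes on the series in an ADME assay on MT4 cells (Homo sapiens) for cytotoxicity, read by MTT assay; a lower number here means that less compound is tolerated, a higher number that more compound is tolerated. Compound 1 `Cc1cc(C)cc(S(=O)(=O)c2c(C(=O)Nc3ccc(O)cc3)[nH]c3ccc(Cl)cc23)c1` gives 18100 nM, and compound 2 `Cc1cc(C)cc(S(=O)(=O)c2c(C(=O)NCc3cccc(O)c3)[nH]c3ccc(Cl)cc23)c1` gives 27000 nM. Between these two lies a 1.5-fold higher number from compound 1 to compound 2 (0.17 log units; within the scatter). Compound 3 `Cc1cc(C)cc(S(=O)(=O)c2c(C(=O)NCc3cc(O)ncn3)[nH]c3ccc(Cl)cc23)c1` gives > 53000 nM, which is a limit of the assay and not a number. Its place is therefore known only through the two steps leading to it: an at least 2.9-fold higher number from compound 1 to compound 3 (0.46 log units; beyond the scatter), and an at least 1.9-fold higher number from compound 2 to compound 3 (0.29 log units; that floor lies within the scatter).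

Next is compound 4 `Cc1cc(C)cc(S(=O)(=O)c2c(C(=O)NCc3ccc(O)c(O)c3)[nH]c3ccc(Cl)cc23)c1`, with 3,4-dihydroxyphenyl in place of 6-hydroxypyrimidin-4-yl on a saturated chain carbon bound to an amide-type nitrogen. The closest measured change is an at least 1.9-fold higher number from compound 2 to compound 3 (0.29 log units; that floor lies within the scatter), where 6-hydroxypyrimidin-4-yl replaced 3-hydroxyphenyl at the same place. Compound 4 goes back to a ring of carbon only, so that step is read in reverse here, and a modest move to a lower number in this assay is expected, of about the size of the two steps into compound 3. Within the data shown here, no measured step covers 3,4-dihydroxyphenyl itself, so the range stays wide, and compound 2 at 27000 nM serves as the nearest anchor. The expected step is an at least 2.5-fold lower number from compound 3 to compound 4 (0.40 log units; beyond the scatter). The estimate for compound 4 is 21000 nM, with an expected range from 9000 nM to 45000 nM.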

Compound 4, half-maximal cytotoxic concentration: 18300 nM
Compound 4: the middle estimate sits 1.1-fold (0.06 log units) above what was measured; the range from low to high includes it.
By their numbers in this assay, from the lowest: compounds 1, 4 and 2 (each within the scatter of the next). At a limit, above all of these: compound 3.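

With an at least 2.8-fold lower number from compound 3 to compound 4 (0.46 log units; beyond the scatter), this exchange on a saturated chain carbon bound to an amide-type nitrogen gives a floor beyond the scatter, whereas the floor of an at least 1.9-fold higher number from compound 2 to compound 3 (0.29 log units; that floor lies within the scatter) lay within it, so the difference between 6-hydroxypyrimidin-4-yl and a ring of carbon only now rests on firmer ground. The added hydroxy on an aromatic carbon does not separate the catechol-type ring from its single-hydroxy partner, with a 1.5-fold lower number from compound 2 to compound 4 (0.17 log units; within the scatter), and the change of linkage and ring together gives a 1.0-fold higher number from compound 1 to compound 4 (0.00 log units; within the scatter), so the three compounds with a ring of carbon only stay within the scatter of one another and compound 3 alone stands apart. Compound 3 remains at a limit of the assay and not a number, so the full size of its step stays unknown: the limit of > 53000 nM in this assay, at which 1 of the 4 values shown sits.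

Going by these compounds, whether the two ring hetero atoms or the hydroxy on that ring carries the step in this assay stays open. Also open, on these data alone, is what an amine or a carboxylic acid in place of that hydroxy, or a longer chain to the ring, would give on the shared core.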